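Series notes: chain shortening from compound 3 to compound 4

This account rests on a few compounds, and the source may have more. Where it says the series, first, only, none or still open, it means among the compounds named here.

The series shares one core carrying a variable group on an aromatic carbon. Compound 1 `COc1nc2ccc(Br)cc2cc1C(c1ccccc1)n1cc(-c2ccc(Br)cc2)nn1` gives 6.92% in an ADME assay on HeLa cells (Homo sapiens) for cytotoxicity, read by sulforhodamine B assay, with a stated time of 48 h, tested at 10 uM; a higher number here means more inhibition at the concentration tested (going by the name of the read-out), a lower number less inhibition. Compound 2 `COc1nc2ccc(Br)cc2cc1C(c1ccccc1)n1cc(-c2ccccc2F)nn1` gives 14.1% in this assay, and compound 3 `CCCCCCCCc1cn(C(c2ccccc2)c2cc3cc(Br)ccc3nc2OC)nn1` gives 0.1% in this assay. Compound 3 stands lowest of the three numbers: its nearest neighbour is compound 1, with a number 6.8 percentage points lower from compound 1 to compound 3 (within the scatter), and its furthest is compound 2, with a number 14 percentage points lower from compound 2 to compound 3 (beyond the scatter); the step of a number 7.2 percentage points higher from compound 1 to compound 2 (within the scatter) between the two aryl analogues is within the scatter.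

Compound 4 `CCCCCc1cn(C(c2ccccc2)c2cc3cc(Br)ccc3nc2OC)nn1` differs from compound 3 by hydrogen in place of propyl on a saturated chain carbon, five bonds along the chain from an aromatic carbon. Among the measured compounds shown here, none of the measured steps shortens a chain; each either replaces an aryl group with octyl or exchanges one aryl for another, so no step bears directly on the change in hand. For the measured compounds named here, the two steps that introduce octyl, a number 6.8 percentage points lower from compound 1 to compound 3 (within the scatter) and a number 14 percentage points lower from compound 2 to compound 3 (beyond the scatter), both end at a number close to no inhibition, and the chain shortening has no measured precedent. The step of a number 2.9 percentage points higher from compound 3 to compound 4 (within the scatter) is therefore expected to stay within the scatter. Compound 4 is estimated at 3% in this assay, with a range from -7% to 13%.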

Compound 4, a percentage reported as inhibition, at one concentration (the size of the read-out at that concentration, not a potency): -9.81%
For compound 4 the middle estimate is 12.8 percentage points above the measured one; the whole stated range lies above it.
By their numbers in this assay, from the lowest: compounds 4, 3, 1 and 2 (each within the scatter of the next, the first and the last beyond it).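

In this assay, among the compounds shown here, hydrogen in place of propyl on a saturated chain carbon, five bonds along the chain from an aromatic carbon, gives a number 9.9 percentage points lower from compound 3 to compound 4 (within the scatter) and so does not separate the two alkyl compounds, the first evidence on chain length at this place. The comparison with the aryl compounds does sharpen: pentyl in place of 4-bromophenyl gives a number 16.7 percentage points lower from compound 1 to compound 4 (beyond the scatter) and pentyl in place of 2-fluorophenyl gives a number 23.9 percentage points lower from compound 2 to compound 4 (beyond the scatter) and thus compound 4 stands apart from both aryl compounds, whereas octyl gave a number 6.8 percentage points lower from compound 1 to compound 3 (within the scatter) and stood apart only from compound 2. No supporting measurement bears on these differences.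

With only pentyl and octyl at this place, the two alkyl compounds define no trend with chain length, and a chain longer than octyl or one as short as ethyl could still behave differently. As far as these compounds go, a chain ending in an amine or a carboxylic acid also remains open, as does any reading of these numbers beyond the single concentration tested.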